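The source may hold more compounds than are shown below. What is called first, only, known or untested is meant among the compounds shown, and "the series" means these compounds.

Measured so far in an ADME assay on the whole organism (Mus musculus, strain CD1) for pharmacokinetics, read by LC-MS, with a stated time of 24 h, at a dose of 5 mg/kg by the oral route; a higher number here means more compound in the circulation at the dose given, a lower number less compound in the circulation:
Compound 1 `CCC(C(=O)O)c1nn(Cc2cn3cc(OCC4CC4)c(Cl)cc3n2)c2ccccc2c1=O`: 2210000 nM
Compound 2 `O=C(O)Cn1nc(Cc2cn3cc(OCC4CC4)c(Cl)cc3n2)c2ccccc2c1=O`: 1040000 nM

Both compounds share the same core and differ only in the acid-bearing side chain. Compound 1 gives the higher of the two numbers in this assay, and the gap to compound 2 lies beyond the scatter, so compound 1 stands at the top of this small set.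

Compound 3 `C[C@H](C(=O)O)c1nn(Cc2cn3cc(OCC4CC4)c(Cl)cc3n2)c2ccccc2c1=O` has not yet been measured. It is compound 1 with one change, (1-carboxyethyl in place of 1-carboxypropyl on an aromatic carbon). The new side chain is shorter by one carbon than that of compound 1 and longer by one carbon than that of compound 2, so it sits between the two measured compounds in chain length.

Within the data shown here, with only two measured compounds and no measured step between them, the expectation can rest only on their two values. Compound 3 is expected to fall between compound 1 and compound 2, and the step of a 1.5-fold lower number from compound 1 to compound 3 (0.17 log units; within the scatter) is expected to be small, possibly within the scatter. The estimated value for compound 3 in this assay is 1500000 nM, with a range from 600000 nM to 3500000 nM.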

Compound 3, maximal plasma concentration: 2610000 nM
Estimate against measurement, compound 3: 1.7-fold (0.24 log units) below; low and high end bracket the measured number.
By their numbers in this assay, from the lowest: compound 2; then compounds 1 and 3 (each within the scatter of the next).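

In this assay, shortening the side chain on this aromatic carbon from 1-carboxypropyl to 1-carboxyethyl gives a 1.2-fold higher number from compound 1 to compound 3 (0.07 log units; within the scatter), so the two compounds cannot be told apart by this read-out. Among these compounds, this is the first comparison in which only this side chain differs, and it shows that the one-carbon difference has no effect here that stands out from the ordinary spread of repeated measurements, at this dose and by this route. The same step also introduces a defined stereocentre in compound 3, and the pair still reads alike, but nothing measured here explains why these two side chains behave alike.

As far as these compounds go, it remains open how far this tolerance extends: whether a longer chain such as 1-carboxybutyl, a ring such as cyclopropane carrying the carboxylic acid, a primary amide in place of that acid, or the mirror-image form of compound 3 would keep the number at this level. A maximal plasma concentration also leaves open how long each compound stays in the circulation after it reaches that peak.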